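The source may report more compounds than this note shows. Statements on the series, on what has been measured and on what is new or still open speak of the compounds shown alone.

Compound 1 `O=C(NS(=O)(=O)c1ccc(Br)cc1)c1ccncc1`: 8700 nM
Compound 2 `O=C(NS(=O)(=O)c1ccccc1)c1ccccn1`: 10600 nM
Compound 3 `O=C(NS(=O)(=O)c1ccc(F)cc1)c1ccccn1`: 11000 nM

In a functional assay on MCF7 cells (Homo sapiens) for antiproliferative activity, read by colorimetric assay and MTT assay, with a stated time of 48 h (a higher number here means a weaker inhibitor, a lower number a stronger inhibitor), the three values lie within the scatter of one another, so compound 3 does not stand apart from the other two. Compound 4 `O=C(NS(=O)(=O)c1ccc(Br)cc1)c1ccccn1` differs from compound 3 by a single change, (bromo in place of fluoro on an aromatic carbon), bromo in place of fluoro on an aromatic carbon. Among the measured compounds shown here, the one measured step at the same place, a 1.0-fold higher number from compound 2 to compound 3 (0.02 log units; within the scatter), put fluoro in place of hydrogen and stayed within the scatter. Compound 1 carries the same bromo but differs elsewhere in the structure, and compound 1 gives 8700 nM. For the measured compounds named here, no measured step exchanges fluoro for bromo directly, so no change beyond the scatter is expected in this assay. The expected change is a 1.2-fold lower number from compound 3 to compound 4 (0.06 log units; within the scatter). Compound 4 is estimated at 9500 nM, with an expected range of 5000 nM to 18000 nM.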

Compound 4, half-maximal inhibitory concentration: 6800 nM
Estimate against measurement, compound 4: 1.4-fold (0.15 log units) above; low and high end bracket the measured number.
By their numbers in this assay, from the lowest: compounds 4, 1, 2 and 3 (each within the scatter of the next).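

In this assay, the place para to a large group tolerates all three substituents seen so far within the scatter: bromo for fluoro gives a 1.6-fold lower number from compound 3 to compound 4 (0.21 log units; within the scatter) and bromo for hydrogen gives a 1.6-fold lower number from compound 2 to compound 4 (0.19 log units; within the scatter) in the same series. With bromo kept, pyridin-2-yl in place of pyridin-4-yl gives a 1.3-fold lower number from compound 1 to compound 4 (0.11 log units; within the scatter) and also stays within the scatter. Nothing available explains these results. Going by these compounds, whether an amine or a carboxylic acid at the same place would give a step beyond the scatter remains open.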